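Swapping chloro for methoxy on a weakly antiproliferative pair

The source may report more compounds than this note shows. Statements on the series, on what has been measured and on what is new or still open speak of the compounds shown alone.

Compound 2 `COc1ccc(-c2nn(-c3ccccc3)cc2C(=O)NCc2cn(Cc3ccc(Cl)cc3)nn2)cc1` was tested in a functional assay on HeLa cells (Homo sapiens) for antiproliferative activity, read by sulforhodamine B assay, with a stated time of 48 h (on this read-out higher numbers stand for weaker inhibition of growth and lower numbers for stronger inhibition of growth), and gave 6400 nM. Its companion compound 1 `COc1ccc(Cn2cc(CNC(=O)c3cn(-c4ccccc4)nc3-c3ccccc3)nn2)cc1` gave 6900 nM in this assay. Compound 2 holds the lower of the two numbers, but the two values sit within the scatter of each other, so nothing separates them. Compound 3 `COc1ccc(Cn2cc(CNC(=O)c3cn(-c4ccccc4)nc3-c3ccc(OC)cc3)nn2)cc1` has not yet been measured. It differs from compound 2 in one place: methoxy in place of chloro on an aromatic carbon, turning a 4-chlorobenzyl into a 4-methoxybenzyl. With no measured step of this kind in the set, the only guide is that both known compounds sit close together, and the exchange is a small one on an outer ring. The expected step of a 1.3-fold higher number from compound 2 to compound 3 (0.10 log units; within the scatter) is therefore small, within the scatter or only slightly toward weaker inhibition. Compound 3 is thus estimated at 8000 nM, with a range from 3000 nM to 20000 nM.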

Compound 3, concentration for 50% growth inhibition: 450 nM
Beside the measured number, compound 3's estimate is 18-fold (1.25 log units) above it, and the stated range ends above it.
By their numbers in this assay, from the lowest: compound 3; then compounds 2 and 1 (each within the scatter of the next).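

Exchanging chloro for methoxy on the benzyl group, para to a large group, turns out not to be a minor edit: it brings a 14-fold lower number from compound 2 to compound 3 (1.15 log units; beyond the scatter), so growth inhibition responds strongly to what sits at this position. Placing methoxy in place of hydrogen on the other aromatic ring, which creates the 4-methoxyphenyl, also brings a large change, a 15-fold lower number from compound 1 to compound 3 (1.19 log units; beyond the scatter). Of these compounds only compound 3 carries both methoxy groups, and nothing measured here accounts for its stronger inhibition.

On these data alone, it remains open whether both methoxy groups are needed together or whether other partners at either position could serve as well. It is also unknown whether an ethoxy or a hydroxyl on the benzyl group would keep the number as low as in compound 3.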